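From compound 3 to compound 4: one group exchanged

The source may hold more compounds than are shown below. What is called first, only, known or untested is meant among the compounds shown, and "the series" means these compounds.

Compound 1 (`CC(C)n1c(Nc2ccccc2)nc2cnc(Nc3ccc(N4CCN(C)CC4)cc3)nc21`) gives 960 nM in a functional assay on NCI-H1975 cells (Homo sapiens) for cytotoxicity, read by MTT assay, with a stated time of 72 h (on this read-out higher numbers stand for weaker inhibition and lower numbers for stronger inhibition), and compound 2 (`CN1CCN(c2ccc(Nc3ncc4nc(Nc5ccccc5)n(-c5ccccc5)c4n3)cc2)CC1`) gives 1830 nM there. Compound 3 (`CC1CCN(c2ccc(Nc3ncc4nc(Nc5ccccc5)n(C5CCCC5)c4n3)cc2)CC1`) stands highest of the three (at 9800 nM), beyond the scatter from both. Compound 4 (`OCCNc1ccc(Nc2ncc3nc(Nc4ccccc4)n(C4CCCC4)c3n2)cc1`) has (2-hydroxyethyl)amino in place of 4-methylpiperidin-1-yl on an aromatic carbon. Among the measured compounds shown here, the only measured step (a 1.9-fold higher number from compound 1 to compound 2 (0.28 log units; within the scatter)) is phenyl in place of isopropyl on an aromatic nitrogen, so no measured step covers this exchange. Compound 2 carries neither group at that carbon and stands lower (at 1830 nM), though it differs elsewhere too, so a moderate, uncertain move to a lower number is expected in this assay. The expected size is only an estimate (a 2.2-fold lower number from compound 3 to compound 4 (0.34 log units; beyond the scatter)). For compound 4 the estimate is 4500 nM (expected range 1500 nM to 14000 nM).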

Compound 4, half-maximal inhibitory concentration: 2810 nM
Compound 4: the middle estimate sits 1.6-fold (0.20 log units) above what was measured; low and high end bracket the measured number.
By their numbers in this assay, from the lowest: compounds 1, 2 and 4 (each within the scatter of the next, the first and the last beyond it); then compound 3.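

Among the compounds shown here, exchanging 4-methylpiperidin-1-yl for (2-hydroxyethyl)amino on this aromatic carbon gives a 3.5-fold lower number from compound 3 to compound 4 (0.54 log units; beyond the scatter) in this assay and is the first measured change at this position. It shows that the number responds to the group held here, and that a group with no ring can stand at this carbon. No measurement shown accounts for this move.

Going by these compounds, whether it follows from the hydroxyl end, the linking nitrogen or the loss of the ring remains open. So does how a morpholine or a longer chain ending in an amine would read here.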